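This account rests on a few compounds, and the source may have more. Where it says the series, first, only, none or still open, it means among the compounds named here.

Measured so far:
- compound 1 `O=C1c2c[n+]([O-])c3ccccc3c2C(=O)c2c1c1ccccc1n2Cc1cn(C[C@H](O)CO)nn1`: 350 nM
- compound 2 `O=C1c2c[n+]([O-])c3ccccc3c2C(=O)c2c1c1ccccc1n2Cc1cn(CC(O)CO)nn1`: 440 nM

Both values come from a functional assay on A-375 cells (Homo sapiens) for cytotoxicity, read by MTT assay, with a stated time of 72 h; on this read-out higher numbers stand for weaker inhibition and lower numbers for stronger inhibition. Going by the values given here, there, compound 2 gives 440 nM and sits within the scatter of compound 1, its only measured neighbour. Compound 3 `CC1(C)O[C@@H](CO)[C@H](Cn2cc(Cn3c4c(c5ccccc53)C(=O)c3c[n+]([O-])c5ccccc5c3C4=O)nn2)O1` has not yet been measured. It keeps the shared core and changes the side chain: 5-(hydroxymethyl)-2,2-dimethyl-1,3-dioxolan-4-yl in place of 1,2-dihydroxyethyl on a saturated chain carbon bound to an aromatic nitrogen. Cut one bond further out, the same change replaces 2,3-dihydroxypropyl with (5-(hydroxymethyl)-2,2-dimethyl-1,3-dioxolan-4-yl)methyl.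

Among the compounds with values here, only one measured step bears on this change, and only weakly. It is a 1.3-fold higher number from compound 1 to compound 2 (0.10 log units; within the scatter), and the two compounds differ solely in the fact that one of compounds 1 and 2 is drawn with a defined configuration and the other without, at the place where they differ. Within the data shown here, that step shows how little the numbers moved when only the drawn configuration of this side chain differed, but no measured compound shows what happens when the group itself is replaced. With so little to go on, no step beyond the scatter is expected, though the uncertainty is wide. The estimated change is a 1.1-fold lower number from compound 2 to compound 3 (0.04 log units; within the scatter). For compound 3 the expected value is 400 nM, with an estimated range from 130 nM to 1200 nM.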

Compound 3, half-maximal inhibitory concentration: 190 nM
Compound 3: the middle estimate sits 2.1-fold (0.32 log units) above what was measured; measured number inside the range.
By their numbers in this assay, from the lowest: compounds 3, 1 and 2 (each within the scatter of the next, the first and the last beyond it).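

In this assay, going by these compounds alone, putting 5-(hydroxymethyl)-2,2-dimethyl-1,3-dioxolan-4-yl in place of the open 1,2-dihydroxyethyl group, on a saturated chain carbon bound to an aromatic nitrogen, gives the first step in this set that lies beyond the scatter: a 2.3-fold lower number from compound 2 to compound 3 (0.36 log units; beyond the scatter). The position therefore accepts a bigger side chain with a five-membered non-aromatic ring and one hydrogen-bond donor fewer, with no loss of cytotoxic strength, but the same change read against the other diol stays within the scatter, a 1.8-fold lower number from compound 1 to compound 3 (0.27 log units; within the scatter), so the modest gain rests on a single comparison. The two steps start from compounds that differ in only one respect: the fact that one of compounds 1 and 2 is drawn with a defined configuration and the other without, at the place where they differ.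

The compounds shown leave open whether the gain belongs to the closed ring, to its two methyl groups or to the two defined stereocentres, as all three arrive together in compound 3. Also open, going by these compounds, is how an amine, a carboxylic acid or a longer chain at this place would read in this assay.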